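The compounds below may be only part of what the source reports. "The series", "measured", "known", "first", "only" and "open" are said of these compounds alone.

In an assay on HEK293 cells for positive allosteric modulation of metabotropic glutamate receptor 5 (Homo sapiens), read by FLIPR, with a stated time of 1 h (on this read-out higher numbers stand for an effect only at larger amounts of compound and lower numbers for an effect already at smaller amounts), compound 2 `O=C(C1CC1)N1CCc2nc(C#Cc3ccccc3)sc2C1` gives > 10000 nM, which is a limit of the assay and not a number. Compound 1 `CN1CCc2nc(C#Cc3cccc(F)c3)sc2C1` gives > 10000 nM, likewise a limit. Every value shown so far sits at the same point, (the limit of > 10000 nM in this assay, at which 2 of the 2 values shown sit), so compound 2 stands exactly where the rest of the data stand, with no measured number of its own.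

Compound 3 `O=C(C1CCCCC1)N1CCc2nc(C#Cc3ccccc3)sc2C1` differs from compound 2 in one place: cyclohexyl in place of cyclopropyl on a carbonyl carbon. Within the data shown here, no pair of measured compounds differing in one place is available, so the size of such a change cannot be read from the data. Among the measured compounds shown here, the only values on hand are limits. The step from compound 2 to compound 3 is expected to be none beyond the scatter, in either direction: a number no higher from compound 2 to compound 3 (the limit leaves the size open). For compound 3 the expected value is 10000 nM, in a range from 3000 nM to 30000 nM, most likely reported again only as a limit.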

Compound 3, half-maximal effective concentration: 167 nM
Beside the measured number, compound 3's estimate is 60-fold (1.78 log units) above it, outside the stated range (below it).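

The group on this carbonyl carbon clearly matters in this assay: cyclohexyl in place of cyclopropyl gives an at least 59-fold lower number from compound 2 to compound 3 (1.77 log units; beyond the scatter), which means that an effect now appears at much smaller amounts of compound. Since the starting point for this step is a limit and not a number, its true size could be larger than the printed figure. Compound 3 is also the only compound shown with a measured number rather than a limit: the limit of > 10000 nM in this assay, at which 2 of the 3 values shown sit.

As far as these compounds go, with only cyclopropyl and cyclohexyl to compare at this position, it remains open whether the value tracks ring size or whether something specific to cyclohexyl is at work, and cyclobutyl, cyclopentyl or phenyl could help to separate these. From the compounds shown here alone, it is also open how an open chain such as tert-butyl, or an amine or carboxylic acid on the cyclohexyl ring, would read in this assay.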